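The source may hold more compounds than are shown below. What is called first, only, known or untested is meant among the compounds shown, and "the series" means these compounds.

Measured in a functional assay on isolated protein for agonist activity at Glucose-dependent insulinotropic receptor (Rattus norvegicus), read by HTRF and cAMP accumulation; a higher number here means a larger maximal response, a lower number a smaller maximal response:
compound 1, `CC(C)S(=O)(=O)c1cnc(O[C@H]2CC[C@H](OC3CCN(C(=O)OC(C)(C)C)CC3)CC2)cn1`: 128%
compound 2, `CC(C)(C)OC(=O)N1CCC(O[C@H]2CC[C@H](Oc3ccc(S(C)(=O)=O)nn3)CC2)CC1`: 86%
compound 3, `CC(C)OC(=O)N1CCC(O[C@H]2CC[C@H](Oc3cnc(S(C)(=O)=O)cn3)CC2)CC1`: 120%

Compound 3 stands second highest of the three. Its nearest neighbour is compound 1, which sits within the usual scatter of it; compound 2 is the furthest, lower and beyond the scatter. Compound 4, `CS(=O)(=O)c1cnc(O[C@H]2CC[C@H](OC3CCN(C(=O)C4(C(F)(F)F)CCCC4)CC3)CC2)cn1`, differs from compound 3 in one place: a group of 9 heavy atoms (6 carbon, 3 fluorine; one five-membered non-aromatic ring of carbon only) in place of a group of 4 heavy atoms (3 carbon, 1 oxygen; no ring), on a carbonyl carbon. No measured pair carries this change, so nothing shown speaks directly to it. Compound 1 and compound 3 differ at both ends of the shared core and still fall within the scatter of each other, so the maximal response has not been sensitive to the changes seen so far. For compound 4 the step of a number 5 percentage points lower from compound 3 to compound 4 (within the scatter) is expected to stay within the scatter, with no clear direction. Compound 4 is estimated at 115%, between 85% and 140%.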

Compound 4, largest response reached (Emax), in percent of the reference or control that the assay uses: 124%
Estimate against measurement, compound 4: 9 percentage points below; low and high end bracket the measured number.
By their numbers in this assay, from the lowest: compound 2; then compounds 3, 4 and 1 (each within the scatter of the next).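

On the carbonyl carbon bound to the amide-type nitrogen in a ring, replacing isopropoxy with the group of 9 heavy atoms gives, in this assay, a number 4 percentage points higher from compound 3 to compound 4 (within the scatter). This position therefore accepts a five-membered carbon ring and 3 fluorine atoms, and loses the hydrogen-bond acceptor of isopropoxy, while the maximal response stays within the scatter. No supporting data explain this outcome. Going by these compounds, whether a dimethylamino group or a carboxylic acid on this carbonyl carbon would keep the response within the scatter remains open. Also open, on these data alone, is whether the same exchange would behave alike on the core of compound 2.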